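Methoxy for methylamino in the azido nucleoside series

The source may hold more compounds than are shown below. What is called first, only, known or untested is meant among the compounds shown, and "the series" means these compounds.

The series is followed in an ADME assay on Vero cells (Chlorocebus sabaeus) for cytotoxicity, with a stated time of 5 days; a lower number here means a stronger inhibitor, a higher number a weaker inhibitor. Compound 1 `C=CCN(C)c1nc(N)nc2c1ncn2[C@H]1C[C@H](N=[N+]=[N-])[C@@H](CO)O1` gives 32000 nM in this assay. Compound 3 `[N-]=[N+]=N[C@H]1C[C@H](n2cnc3c(NCCCCCO)nc(N)nc32)O[C@@H]1CO` reaches only a limit of this assay, > 100000 nM. Between the two there is an at least 3.1-fold higher number from compound 1 to compound 3 (0.49 log units; beyond the scatter). Compound 2 `CNc1nc(Cl)nc2c1ncn2[C@H]1C[C@H](N=[N+]=[N-])[C@@H](CO)O1` likewise shows only a limit in this assay, > 100000 nM, so its standing among the numbers cannot be fixed more closely. Its value is the limit of > 100000 nM in this assay, at which 2 of the 3 values shown sit. Compound 4 `COc1nc(Cl)nc2c1ncn2[C@H]1C[C@H](N=[N+]=[N-])[C@@H](CO)O1` differs from compound 2 by methoxy in place of methylamino on an aromatic carbon. Going by the values given here, the only measured step, from compound 1 to compound 3, concerns a different group at a different place on the shared core and so gives no direct guide to this exchange; no measured pair swaps methylamino for methoxy. With compound 2 already at the limit and nothing in the data pointing to a stronger inhibitor, the expected step is a step that the limit leaves unreadable from compound 2 to compound 4, within the scatter. Compound 4 is accordingly expected to come out at 150000 nM, with a range of 60000 nM to 400000 nM, most likely as a limit again.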

Compound 4, half-maximal inhibitory concentration: > 100000 nM
Compound 4 gave a limit, no number; the forecaster's own chance of this, stated with the estimate: 75%; the middle value lies beyond the limit too.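

In this assay, going by these compounds alone, compound 2 and compound 4 both stop at a limit of the assay, and no step between them can be read. From the compounds shown here alone, whether methoxy in place of methylamino on an aromatic carbon shifts the number at all remains open.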